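Swapping 3-bromobenzyl for 2,4-difluorobenzyl in compound 3

This account rests on a few compounds, and the source may have more. Where it says the series, first, only, none or still open, it means among the compounds named here.

Values measured in a functional assay on HeLa cells (Homo sapiens) for antiproliferative activity, read by MTT assay, with a stated time of 48 h (a lower number here means a stronger inhibitor, a higher number a weaker inhibitor), follow
Compound 1 `Brc1cccc(CSc2nnc(-c3cnccn3)o2)c1` gives 30300 nM
Compound 2 `Brc1ccccc1CSc1nnc(-c2cnccn2)n1-c1ccccc1` gives > 50000 nM which is a limit of the assay and not a number
Compound 3 `Brc1cccc(CSc2nnc(-c3cnccn3)n2-c2ccccc2)c1` gives 9580 nM

Compound 3 carries the lowest number here (9580 nM), and its gap to compound 1 (30300 nM) lies beyond the usual scatter. Compound 4 `Fc1ccc(CSc2nnc(-c3cnccn3)n2-c2ccccc2)c(F)c1` has not yet been measured. It puts 2,4-difluorophenyl in place of 3-bromophenyl on a saturated chain carbon bound to a sulfur.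

For the measured compounds named here, only one measured step bears on this change. Putting 3-bromophenyl in place of 2-bromophenyl at that same place gave a clear shift in this assay (an at least 5.2-fold lower number from compound 2 to compound 3 (0.71 log units; beyond the scatter)). That step shows that the group at this place can move the number. Compound 4 gives up the 3-bromophenyl of compound 3 (9580 nM), so a modestly higher number is expected. Going by the values given here, no measured compound carries fluorine, so the size of the step remains uncertain. A result at the limit of > 50000 nM in this assay, at which 1 of the 3 values shown sits, also remains possible for compound 4.

The expected change is a 1.7-fold higher number from compound 3 to compound 4 (0.22 log units; within the scatter) in this read-out. In this assay compound 4 is estimated at 16000 nM within an expected range from 6000 nM to 45000 nM as its lower and upper ends.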

Compound 4, half-maximal inhibitory concentration: 12500 nM
Beside the measured number, compound 4's estimate is 1.3-fold (0.11 log units) above it, and the stated range covers the measured number.
By their numbers in this assay, from the lowest: compounds 3 and 4 (each within the scatter of the next); then compound 1. At a limit, above all of these: compound 2.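

In this assay, the change shows that bromine is not needed on the ring at this place, on a saturated chain carbon bound to a sulfur: the 2,4-difluorophenyl group of compound 4 cannot be told apart from the 3-bromophenyl group of compound 3, with a 1.3-fold higher number from compound 3 to compound 4 (0.12 log units; within the scatter). The same group also stands clearly apart from the 2-bromophenyl group, with an at least 4.0-fold lower number from compound 2 to compound 4 (0.60 log units; beyond the scatter), so the poor result of that group is not shared by 2,4-difluorophenyl, even though both names carry a 2. Compound 2 remains a limit of the assay and not a number: the limit of > 50000 nM in this assay, at which 1 of the 4 values shown sits.

Every group shown at this place is a halogen-bearing phenyl ring, so it stays open whether halogen on the ring matters at all, as an unsubstituted phenyl, a methoxyphenyl or an aminophenyl ring could show. From the compounds shown here alone, it also stays open whether a longer chain between the sulfur and the ring, or a ring containing nitrogen such as pyridyl, would move the number well away from those of compound 3 and compound 4.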